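Adding a Second Chloro to Compound 3

The source may report more compounds than this note shows. Statements on the series, on what has been measured and on what is new or still open speak of the compounds shown alone.

Of the compounds shown here, three have been measured in a functional assay on SNB-19 cells (Homo sapiens) for inhibition, read by sulforhodamine B assay, with a stated time of 48 h; a lower number here means a stronger inhibitor of growth, a higher number a weaker inhibitor of growth. Among the compounds with values here, compound 1 `N#C/C(=C\N1CCN(C(=O)c2ccco2)C1=S)C(=O)Nc1ccc(Cl)cc1` gives 27600 nM, and compound 2 `N#C/C(=C\N1CCN(C(=O)c2ccco2)C1=S)C(=O)c1ccccc1` gives 39700 nM; the one change between them, a 1.4-fold higher number from compound 1 to compound 2 (0.16 log units; within the scatter), is too small to count. Compound 3 `O=CN1CCN(c2ccc(Cl)cc2)C1=S` has a smaller core than the other two and gives 15600 nM, the lowest of the three numbers, yet its gap to compound 1 lies within the scatter, so it cannot be called the stronger inhibitor; only its gap to compound 2 lies beyond the scatter.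

Compound 4 `O=CN1CCN(c2ccc(Cl)c(Cl)c2)C1=S` is compound 3 with one change: chloro in place of hydrogen on an aromatic carbon. Within the data shown here, none of the measured steps concerns adding a chloro group to an aromatic ring; the single measured step swaps a whole group on a carbonyl carbon within a different core. Among the measured compounds shown here, there is therefore no measured step that bears on this change, and the expectation rests on the unchanged core of compound 3 alone. The estimated step of a 1.3-fold lower number from compound 3 to compound 4 (0.11 log units; within the scatter) is expected to stay within the scatter. Compound 4 is accordingly expected to give about 12000 nM in this assay, with a likely range from 4000 nM to 40000 nM.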

Compound 4, concentration for 50% growth inhibition: 17500 nM
The estimate for compound 4 lay 1.5-fold (0.16 log units) below the measured number; the range from low to high includes it.
By their numbers in this assay, from the lowest: compounds 3, 4, 1 and 2 (each within the scatter of the next, the first and the last beyond it).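

In this assay, chloro in place of hydrogen on an aromatic carbon, ortho to a chloro group and meta to a group of 8 heavy atoms, gives a 1.1-fold higher number from compound 3 to compound 4 (0.05 log units; within the scatter). Within the data shown here, the only earlier step concerned a carbonyl carbon in a different core, so this is the first measured change on the aromatic ring of compound 3, and it shows that this position can take a second chloro with no change that can be told apart from the scatter. Nothing available explains why the number holds steady, and no measurement of any property of the two compounds bears on this result.

Chloro is the only group seen at this position, and a single pair cannot show whether an amine, a carboxylic acid, a methoxy group or a longer chain there would move the number beyond the scatter. From the compounds shown here alone, it also remains open whether the same added chloro would stay within the scatter on the chlorinated ring of compound 1, whose core is larger than that of compound 3.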